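The source may hold more compounds than are shown below. What is called first, only, known or untested is meant among the compounds shown, and "the series" means these compounds.

Series notes. Compound 1 `COc1ccc(C(=O)c2cc(OC)c(OC)c(OC)c2)cc1NC(=O)/C=C/c1cc(OC)c(OC)c(OC)c1` and compound 2 `COc1ccc(C(=O)c2cc(OC)c(OC)c(OC)c2)cc1NC(=O)/C=C/c1ccc(C(F)(F)F)cc1` share one core and differ only at the aryl end of the chain. In a functional assay on ME-180 cells (Homo sapiens) for cytotoxicity, read by MTT assay, with a stated time of 72 h (on this read-out lower numbers stand for stronger inhibition and higher numbers for weaker inhibition), compound 1 gives 2100 nM, while compound 2 gives 800 nM. Going by the values given here, the change a 2.6-fold lower number from compound 1 to compound 2 (0.42 log units; beyond the scatter) is the only measured step, so compound 2 stands at the lower number of the two. Compound 3 `COc1cc(/C=C/C(=O)Nc2cc(C(=O)c3cc(OC)c(OC)c(OC)c3)ccc2OC)ccc1F` is not yet measured; its change from compound 2 is 4-fluoro-3-methoxyphenyl in place of 4-(trifluoromethyl)phenyl on a double-bonded chain carbon bound to a double-bonded chain carbon. Among the compounds with values here, no measured step covers this exact exchange. Within the data shown here, the one step that bears on it, a 2.6-fold lower number from compound 1 to compound 2 (0.42 log units; beyond the scatter), shows the trifluoromethyl-bearing ring giving the lower number against a methoxy-bearing ring, and compound 3 returns a methoxy to that ring while keeping a single fluorine. In this assay compound 3 is therefore expected to sit between the two measured values, a step of a 1.6-fold higher number from compound 2 to compound 3 (0.21 log units; within the scatter) toward a higher number, estimated at 1300 nM with a range of 550 nM to 3000 nM.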

Compound 3, half-maximal inhibitory concentration: 15500 nM
Estimate against measurement, compound 3: 12-fold (1.08 log units) below; measured number above the stated range.
By their numbers in this assay, from the lowest: compound 2; then compound 1; then compound 3.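

In this assay, the aryl end of the chain proves far more sensitive than the earlier pair suggested: 4-fluoro-3-methoxyphenyl gives the highest number of the three, with a 19-fold higher number from compound 2 to compound 3 (1.29 log units; beyond the scatter) against 4-(trifluoromethyl)phenyl and a 7.4-fold higher number from compound 1 to compound 3 (0.87 log units; beyond the scatter) against 3,4,5-trimethoxyphenyl. Methoxy content alone does not order these rings, since 4-(trifluoromethyl)phenyl, with no methoxy, and 3,4,5-trimethoxyphenyl, with more methoxy than 4-fluoro-3-methoxyphenyl, both give lower numbers. No measurement at hand accounts for these steps.

Still open, from the compounds shown here alone, is whether the fluorine, the methoxy or their combination sets the higher number, which 4-fluorophenyl and 3-methoxyphenyl rings at this place could separate. Also open, going by these compounds, is how an amine or a carboxylic acid on this ring would read.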